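This account rests on a few compounds, and the source may have more. Where it says the series, first, only, none or still open, it means among the compounds named here.

Compound 1 `CC(C)c1noc(-c2cccc(CNc3ccc4[nH]nc(C(=O)O)c4c3)c2O)n1` is the starting point of this step. Within the data shown here, in an assay on isolated protein for inhibition of 2-Hydroxyacid oxidase 1 (Homo sapiens), with stated times of 30 min and 15 min (on this read-out lower numbers stand for stronger inhibition and higher numbers for weaker inhibition), compound 1 gives 47 nM, the lowest of the two numbers measured so far. Compound 2 `Cc1csc(-c2cccc(CN(C)c3ccc4[nH]nc(C(=O)O)c4c3)c2)n1` in this assay gives 650 nM, a much higher number; the two compounds differ in more than one place, so this gap is a comparison of values only, not a single step. Compound 3 `CN(C)C(=O)c1cccc(CNc2ccc3[nH]nc(C(=O)O)c3c2)c1O` has not yet been measured. It differs from compound 1 in one place: dimethylcarbamoyl in place of 3-isopropyl-1,2,4-oxadiazol-5-yl on an aromatic carbon. The group that leaves carries a ring, the group that enters has no ring, and the shared core of compound 1 is kept. Among the measured compounds shown here, no measured pair shows this exact change, so its effect must be estimated. Compound 3 is expected to inhibit somewhat less strongly than compound 1, with an estimated step of a 5.3-fold higher number from compound 1 to compound 3 (0.73 log units; beyond the scatter). For compound 3 the expected value in this assay is 250 nM, with a range from 80 nM to 800 nM.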

Compound 3, half-maximal inhibitory concentration: > 30000 nM
Compound 3: a limit, no number; the forecaster's own chance of this, stated with the estimate: 5%; at least 120-fold (2.07 log units) between middle value and limit.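

In this assay, the group on this aromatic carbon, ortho to a hydroxy group, proves decisive: dimethylcarbamoyl in place of 3-isopropyl-1,2,4-oxadiazol-5-yl gives an at least 630-fold higher number from compound 1 to compound 3 (2.80 log units; beyond the scatter). Compound 1 and compound 2 differ in more than one place, so they could not isolate any single change in this way. The value of compound 3 is a limit and not a number, so the true size of this step remains unknown: the limit of > 30000 nM in this assay, at which 1 of the 3 values shown sits.

This single step replaces the ring and the isopropyl group together, leaving open which of them matters for inhibition. It is also unsettled whether another group on this carbon, such as a phenyl ring or a primary amide, would give a value closer to that of compound 1.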